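The compounds below may be only part of what the source reports. "The series", "measured", "known", "first", "only" and "open" are said of these compounds alone.

In a functional assay on IGROV-1 cells (Homo sapiens) for inhibition, read by sulforhodamine B assay, with a stated time of 48 h, tested at 10 uM (a lower number here means less inhibition of growth, a higher number more inhibition of growth at the concentration tested), compound 1 (`COc1ccc(-c2nc3sc(-c4ccccc4)cn3n2)cc1`) gives 52% and compound 2 (`Clc1ccc(-c2cn3nc(-c4ccccc4)nc3s2)cc1`) gives 55% as its reading, two numbers within the scatter of each other, while compound 3 (`COc1ccc(-c2nc3sc(-c4ccc(Cl)cc4)cn3n2)cc1`) reaches 92.9% as the top reading of the set. Compound 2 therefore sits level with compound 1 and well under compound 3.

The change to compound 4 (`c1ccc(-c2nc3sc(-c4ccccc4)cn3n2)cc1`) is hydrogen in place of chloro on an aromatic carbon and amounts to hydrogen in place of chloro on an aromatic carbon, turning 4-chlorophenyl to phenyl. The closest guide is the same exchange run in reverse: chloro in place of hydrogen gave a number 40.9 percentage points higher from compound 1 to compound 3 (beyond the scatter) with methoxy present. Methoxy in place of hydrogen gave a number 37.9 percentage points higher from compound 2 to compound 3 (beyond the scatter) on the chloro compound, so each group has shown a large step. Among the measured compounds shown here, no chloro step has been measured without methoxy, so its size here is uncertain, but a large fall beyond the scatter is expected. The estimated change is a number 30 percentage points lower from compound 2 to compound 4 (beyond the scatter) overall. For compound 4 the expected value is 25% with an estimated range from 5% to 48% in this measurement.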

Compound 4, percent growth inhibition at one concentration: 43%
Estimate against measurement, compound 4: 18 percentage points below; low and high end bracket the measured number.
By their numbers in this assay, from the lowest: compounds 4, 1 and 2 (each within the scatter of the next, the first and the last beyond it); then compound 3.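

Among the compounds shown here, without a methoxy group on the shared core, losing the chloro from the 4-chlorophenyl group costs far less than the earlier steps suggested: in this assay, hydrogen in place of chloro gives a number 12 percentage points lower from compound 2 to compound 4 (beyond the scatter) and hydrogen in place of methoxy gives a number 9 percentage points lower from compound 1 to compound 4 (within the scatter). Among these four compounds, the size of the chloro step therefore depends on whether methoxy is present, and the high reading appears only in compound 3, which carries both groups: the same change on two cores in this assay, a number 40.9 percentage points higher (beyond the scatter) from compound 1 to compound 3 and a number 12 percentage points higher (beyond the scatter) from compound 4 to compound 2, 28.9 percentage points apart, beyond the scatter of two such steps. The methoxy step likewise depends on whether chloro is present: the same change on two cores in this assay, a number 37.9 percentage points higher (beyond the scatter) from compound 2 to compound 3 and a number 9 percentage points higher (within the scatter) from compound 4 to compound 1, 28.9 percentage points apart, beyond the scatter of two such steps.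

As far as these compounds go, what a bromo group in place of chloro, or an amine in place of methoxy, would do remains open. These readings also come from a single concentration, leaving open how the compounds would rank across a range of concentrations.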